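The compounds below may be only part of what the source reports. "The series", "measured", "known", "first", "only" and "open" are said of these compounds alone.

Three compounds have been measured in a functional assay on OVCAR-3 cells (Homo sapiens) for inhibition, read by sulforhodamine B assay, with a stated time of 48 h; a higher number here means a weaker inhibitor of growth, a lower number a stronger inhibitor of growth:

Compound 1 `CC1=CC[C@H](C(C)(C)NC(=S)N/N=C/c2ccccc2)CC1`: 8700 nM
Compound 2 `COc1ccc(/C=N/NC(=S)NC(C)(C)[C@H]2CC=C(C)CC2)cc1`: 7900 nM
Compound 3 `CC1=CC[C@H](C(C)(C)NC(=S)N/N=C/c2ccc(Cl)cc2)CC1`: 8600 nM

Compound 3 stands second highest of the three numbers, with a 1.0-fold lower number from compound 1 to compound 3 (0.01 log units; within the scatter) and a 1.1-fold higher number from compound 2 to compound 3 (0.04 log units; within the scatter) both within the scatter. Compound 4 `CC1=CC[C@H](C(C)(C)NC(=S)N/N=C/c2cccs2)CC1` differs from it by thiophen-2-yl in place of 4-chlorophenyl on a carbon with a double bond to nitrogen. The measured steps bear on this change only loosely: each of them alters a substituent on the aromatic ring, and none of them exchanges the ring itself, yet all three stayed within the scatter. Compound 4 is therefore expected to show no step beyond the scatter, a 1.0-fold lower number from compound 3 to compound 4 (0.01 log units; within the scatter). The estimate for compound 4 in this assay is 8500 nM, with a range from 4000 nM to 18000 nM.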

Compound 4, concentration for 50% growth inhibition: 13100 nM
For compound 4 the middle estimate is 1.5-fold (0.19 log units) below the measured one; the range from low to high includes it.
By their numbers in this assay, from the lowest: compounds 2, 3, 1 and 4 (each within the scatter of the next).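

In this assay, among these compounds, the earlier steps altered only a substituent on the aromatic ring, whereas this change replaces the ring itself on the carbon with a double bond to nitrogen. Thiophen-2-yl stays within the scatter of all three six-membered aromatic rings (a 1.5-fold higher number from compound 3 to compound 4 (0.18 log units; within the scatter); a 1.7-fold higher number from compound 2 to compound 4 (0.22 log units; within the scatter); a 1.5-fold higher number from compound 1 to compound 4 (0.18 log units; within the scatter)). No measured evidence accounts for these steps.

On these data alone, it remains open whether a pyridine ring at this place, or an amine or a carboxylic acid on the ring, would step beyond the scatter. As far as these compounds go, what a change to the shared core would do also remains open.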